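Branching the Ester Chain of Compound 1

A few compounds are considered here, and "the series" means these few. Any claim that something is new, unique, unknown or untested is made for them only; others in the source may bear on it.

Compound 1 `CCCCc1nc(C(C)C)c(CC(=O)OC)c(=O)n1Cc1ccc(-c2ccccc2-c2noc(=O)[nH]2)cc1` gives the lowest of the three numbers in an ADME assay on microsomes from liver (Mus musculus) for metabolic stability, with a stated time of 30 min (a lower number here means that less of the compound is left, a higher number that more of the compound is left), at 9.4%. Compound 2 `CCCCc1nc(C(C)C)c(CC(=O)OCCC)c(=O)n1Cc1ccc(-c2ccccc2-c2noc(=O)[nH]2)cc1` gives 12.6%, and compound 3 `CCCCCOC(=O)Cc1c(C(C)C)nc(CCCC)n(Cc2ccc(-c3ccccc3-c3noc(=O)[nH]3)cc2)c1=O` gives 19.7%. Compound 4 `CCCCc1nc(C(C)C)c(CC(=O)OC(CC)CC)c(=O)n1Cc1ccc(-c2ccccc2-c2noc(=O)[nH]2)cc1` differs from compound 1 by pentan-3-yl in place of methyl on an oxygen next to a carbonyl group. The closest measured steps both lengthen the chain on that oxygen: a number 3.2 percentage points higher from compound 1 to compound 2 (within the scatter) and a number 10.3 percentage points higher from compound 1 to compound 3 (beyond the scatter). The gain from a pentyl chain in compound 3 suggests that five carbons, here arranged as pentan-3-yl, are expected to raise the number modestly, while a shift as small as that from compound 1 to compound 2 remains possible. The expected step is therefore a number 8.6 percentage points higher from compound 1 to compound 4 (within the scatter), so compound 4 is estimated at 18%, between 8% and 30%.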

Compound 4, percent of the compound remaining: 14.6%
The estimate for compound 4 lay 3.4 percentage points above the measured number, within the range that was stated.
By their numbers in this assay, from the lowest: compounds 1, 2, 4 and 3 (each within the scatter of the next, the first and the last beyond it).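

In this assay the branched pentan-3-yl on the oxygen next to a carbonyl group gives a number 5.2 percentage points higher from compound 1 to compound 4 (within the scatter) and so, unlike the straight pentyl chain, does not clear the scatter from methyl. The branched group also cannot be told apart from either straight chain, with a number 5.1 percentage points lower from compound 3 to compound 4 (within the scatter) and a number 2 percentage points higher from compound 2 to compound 4 (within the scatter). Nothing shown bears on the reason for these numbers. The compounds shown leave open how a cyclopentyl group or a longer chain such as heptyl on that oxygen would read, and how the carboxylic acid in place of the ester would compare.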